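The source may hold more compounds than are shown below. What is called first, only, known or untested is meant among the compounds shown, and "the series" means these compounds.

For the measured compounds named here, in an ADME assay on Raji cells (Homo sapiens) for cytotoxicity, with a stated time of 72 h (a lower number here means that less compound is needed, a higher number that more compound is needed for the effect), compound 3 `COC(=O)c1cccc(NC(=O)Nc2cc(C)nc3ccccc23)c1` gives 26000 nM, the only true number among the measured compounds. Compound 1 `COc1ccc(NC(=O)Nc2cc(C)nc3ccccc23)cc1OC` reports > 25000 nM, which is a limit of the assay. Compound 2 `Cc1cc(NC(=O)Nc2cccc(F)c2)c2ccccc2n1` reports > 25000 nM, which is also a limit of the assay. The picture so far is therefore set largely by the limit of > 25000 nM in this assay, at which 2 of the 3 values shown sit.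

The next compound, compound 4 `COc1cccc(NC(=O)Nc2cc(C)nc3ccccc23)c1`, keeps the shared core and changes one group: methoxy in place of methoxycarbonyl on an aromatic carbon. In words, this is methoxy in place of methoxycarbonyl on an aromatic carbon, meta to a large group.

Going by the values given here, only one measured step changes a group on an aromatic carbon in this way, and it offers no size to carry over: a step that the limit leaves unreadable from compound 2 to compound 3. Compound 1, which also carries methoxy, gives only its limit of > 25000 nM, so it offers no sign of a large step either. With compound 3 at 26000 nM as the sole numerical anchor, no step beyond the usual scatter is expected in this assay, and no direction can be favoured with confidence. The expected change is a 1.2-fold higher number from compound 3 to compound 4 (0.06 log units; within the scatter). Compound 4 is estimated at 30000 nM, with an expected range from 17000 nM to 50000 nM.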

Compound 4, half-maximal effective concentration: > 25000 nM
Compound 4 gave a limit, no number (the forecaster's own chance of this, stated with the estimate: 70%); the middle value does not contradict the limit.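

In this assay compound 4 gives > 25000 nM, which is a limit of the assay, so its steps from compound 1, compound 2 and compound 3 cannot be read. The compounds shown leave open how large any effect of changing the group on this aromatic ring is, because most values rest on a single limit: the limit of > 25000 nM in this assay, at which 3 of the 4 values shown sit.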